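The compounds below may be only part of what the source reports. "The series", "measured", "known", "first", "only" and "open" are said of these compounds alone.

Three compounds have been measured in a functional assay on CRL2813 cells (Homo sapiens) for antiproliferative activity, read by sulforhodamine B assay, with a stated time of 3 days, in the presence of a further agent that is not named here; a higher number here means a weaker inhibitor, a lower number a stronger inhibitor:
Compound 1, `O=C(Nc1cccc(C(F)(F)F)c1)N[C@H]1CC[C@H](Oc2cccc(F)c2)CC1`, gives 4300 nM.
Compound 2, `O=C(Nc1cccc(C(F)(F)F)c1)N[C@H]1CC[C@@H](Oc2ccc(F)cc2)CC1`, gives 6000 nM.
Compound 3, `O=C(Nc1cccc(C(F)(F)F)c1)N[C@H]1CC[C@H](Oc2ccccc2F)CC1`, gives 2800 nM.

All three share one core and differ only in the fluorophenyl group held on an oxygen on a saturated carbon. Compound 3 has the lowest number of the three. Its nearest neighbour is compound 1, and the step of a 1.5-fold lower number from compound 1 to compound 3 (0.19 log units; within the scatter) lies within the scatter, so the two cannot be told apart. Compound 2 stands furthest away: in this assay compound 3 gives 2800 nM, while compound 2 gives 6000 nM, a gap beyond the scatter. For that pair only the two values themselves can be compared.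

Compound 4, `O=C(Nc1cccc(C(F)(F)F)c1)N[C@H]1CC[C@H](Oc2ccc(C(F)(F)F)cc2)CC1`, changes the same group: 4-(trifluoromethyl)phenyl in place of 2-fluorophenyl on an oxygen on a saturated carbon. Among the measured compounds shown here, only one measured step touches this group, the move from compound 1 to compound 3, and it stayed within the scatter. No measurement covers the exchange of fluorine for trifluoromethyl. The values of compound 2 and compound 3 suggest a somewhat higher number for compound 4, but the untested trifluoromethyl keeps the range wide. The step from compound 3 to compound 4 is expected to be a 1.8-fold higher number from compound 3 to compound 4 (0.25 log units; within the scatter). Compound 4 is estimated at 5000 nM, with a range from 2000 nM to 14000 nM.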

Compound 4, half-maximal inhibitory concentration: 660 nM
Beside the measured number, compound 4's estimate is 7.6-fold (0.88 log units) above it; measured number below the stated range.
By their numbers in this assay, from the lowest: compound 4; then compounds 3, 1 and 2 (each within the scatter of the next, the first and the last beyond it).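

Among the compounds shown here, until this result, the only comparison at this position was between two fluorophenyl groups, and that step stayed within the scatter, so the group on this oxygen could have seemed to matter little. In this assay, for the compounds shown here, the exchange for 4-(trifluoromethyl)phenyl brings a 4.2-fold lower number from compound 3 to compound 4 (0.63 log units; beyond the scatter) and a 6.5-fold lower number from compound 1 to compound 4 (0.81 log units; beyond the scatter) and thus gives the first steps at this position that lie beyond the scatter, showing that the number can respond to what this oxygen carries. No measurement at hand bears on the reason for these steps.

The compounds shown leave open whether the lower number goes with the trifluoromethyl group itself or with its place on the phenyl ring, since compound 2, the one 4-fluorophenyl compound, also differs from compound 4 in the arrangement at the saturated ring carbon. Also open, going by these compounds, is how a chlorine atom, a nitrile or a methoxy group would compare with trifluoromethyl on this phenyl ring.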